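Aryl swap at the saturated ring carbon of the shared core

The source may report more compounds than this note shows. Statements on the series, on what has been measured and on what is new or still open speak of the compounds shown alone.

Measured compounds in an assay on SH-SY5Y cells for inhibition of Voltage-dependent L-type calcium channel subunit alpha-1D (Homo sapiens), read by calcium flux, with a stated time of 15 min; on this read-out higher numbers stand for weaker inhibition and lower numbers for stronger inhibition: compound 1 `CCOC(=O)C1=C(C)NC(c2ccc(Cl)cc2)=CC1c1ccc(Cl)cc1`, 28400 nM; compound 2 `CCOC(=O)C1=C(C)NC(c2ccccc2)=CC1c1ccc(OC)cc1`, 29800 nM; compound 3 `COc1ccc(C2C=C(c3ccccc3)NC(C)=C2C(=O)SC(C)(C)C)cc1`, 26800 nM.

All three numbers sit within the scatter of one another; compound 1 lies nearest to compound 2 and furthest from compound 3, with neither gap beyond the scatter. Going by the values given here, the only single-point step in hand is a 1.1-fold lower number from compound 2 to compound 3 (0.05 log units; within the scatter), which concerns the carbonyl substituent and not the aryl group. Compound 4 `CCOC(=O)C1=C(C)NC(c2ccc(Cl)cc2)=CC1c1ccccc1[N+](=O)[O-]` differs from compound 1 by 2-nitrophenyl in place of 4-chlorophenyl on a saturated ring carbon. Among the compounds with values here, no measured step touches this position, so nothing argues for a shift beyond the scatter in this assay. Compound 4 is therefore expected near compound 1, at 20000 nM with a range of 4000 nM to 60000 nM; the expected step is a 1.4-fold lower number from compound 1 to compound 4 (0.15 log units; within the scatter).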

Compound 4, half-maximal inhibitory concentration: 57100 nM
Beside the measured number, compound 4's estimate is 2.9-fold (0.46 log units) below it; low and high end bracket the measured number.
By their numbers in this assay, from the lowest: compounds 3, 1, 2 and 4 (each within the scatter of the next, the first and the last beyond it).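

Going by these compounds alone, this is the first measured step at the saturated ring carbon: in this assay, 2-nitrophenyl in place of 4-chlorophenyl gives a 2.0-fold higher number from compound 1 to compound 4 (0.30 log units; within the scatter) and so no shift beyond the scatter. On the core of compound 1, this position thus carries either aryl group without a separable change in the read-out. No available evidence bears on the reason for this result.

As far as these compounds go, whether an amine or a carboxylic acid on the phenyl ring at this carbon would separate from compound 1 stays open. So does the reading of a cyclohexyl group there in place of the aryl group.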